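A few compounds are considered here, and "the series" means these few. Any claim that something is new, unique, unknown or untested is made for them only; others in the source may bear on it.

Compound 1 `CCOc1ccc2oc(/C=C/[S+](C)[O-])cc(=O)c2c1` gives 4900 nM in a functional assay on DLD-1 cells (Homo sapiens) for cytotoxicity, with a stated time of 48 h; on this read-out lower numbers stand for stronger inhibition and higher numbers for weaker inhibition.
Compound 2 `CCC(=O)Oc1ccc2oc(/C=C/[S+](C)[O-])cc(=O)c2c1` gives 9000 nM in this assay.
Compound 3 `CCCC(=O)Oc1ccc2oc(/C=C/[S+](C)[O-])cc(=O)c2c1` gives 8700 nM in this assay.

Compound 3 stands second highest of the three numbers; its nearest neighbour is compound 2 and its furthest is compound 1, and both gaps lie within the scatter, as a 1.0-fold lower number from compound 2 to compound 3 (0.01 log units; within the scatter) and a 1.8-fold higher number from compound 1 to compound 3 (0.25 log units; within the scatter) show. Compound 4 `C[S+]([O-])/C=C/c1cc(=O)c2cc(Br)ccc2o1` has not yet been measured in this assay.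

bromo in place of (propylcarbonyl)oxy on an aromatic carbon

Within the data shown here, the two measured steps that alter this position, a 1.8-fold higher number from compound 1 to compound 3 (0.25 log units; within the scatter) and a 1.0-fold lower number from compound 2 to compound 3 (0.01 log units; within the scatter), were both within the scatter, but each kept an oxygen on the ring, whereas bromo carries none, so no measured step shows this exchange directly. The step expected in this assay is therefore modest: a 1.5-fold lower number from compound 3 to compound 4 (0.16 log units; within the scatter). Compound 4 is estimated at 6000 nM, with a range from 2000 nM to 20000 nM.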

Compound 4, half-maximal inhibitory concentration: 4500 nM
For compound 4 the middle estimate is 1.3-fold (0.12 log units) above the measured one; the measured number falls inside the stated range.
By their numbers in this assay, from the lowest: compounds 4, 1, 3 and 2 (each within the scatter of the next).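

Bromo, a single heavy atom, sits within the scatter of all three oxygen-linked groups in this assay: of (propylcarbonyl)oxy (a 1.9-fold lower number from compound 3 to compound 4 (0.29 log units; within the scatter)), of propanoyloxy (a 2.0-fold lower number from compound 2 to compound 4 (0.30 log units; within the scatter)) and of ethoxy (a 1.1-fold lower number from compound 1 to compound 4 (0.04 log units; within the scatter)). Among these compounds, then, an oxygen on this aromatic carbon is not needed to keep the number in this range. Nothing measured here gives a cause for this result.

Going by these compounds, what an amine, a carboxylic acid or a longer chain would do on this aromatic carbon stays open. So does whether any group here can move the number beyond the scatter.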